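One Aryl Swap, Measured Once, Expected Again

The compounds below may be only part of what the source reports. "The series", "measured", "known", "first", "only" and "open" are said of these compounds alone.

Compound 1: `COc1ccc(C=C(C(=O)/C=C/c2cccc(OC)c2OC)C(=O)/C=C/c2cccc(OC)c2OC)cc1OC` — 200 nM
Compound 2: `COc1cccc(/C=C/C(=O)C(=Cc2ccc(O)c(F)c2)C(=O)/C=C/c2cccc(OC)c2OC)c1OC` — 220 nM
Compound 3: `COc1ccc(OC)c(/C=C/C(=O)C(=Cc2ccc(OC)c(OC)c2)C(=O)/C=C/c2cc(OC)ccc2OC)c1` — 260 nM

Of the compounds shown here, three have been tested in a functional assay on HepG2 cells (Homo sapiens) for antiproliferative activity, read by sulforhodamine B assay, with a stated time of 48 h (on this read-out lower numbers stand for stronger inhibition and higher numbers for weaker inhibition), and all three values lie within the scatter of one another, so no order among them can be drawn. Compound 1 and compound 2 share a core and differ by 3-fluoro-4-hydroxyphenyl in place of 3,4-dimethoxyphenyl on a double-bonded chain carbon bound to a double-bonded chain carbon; this change gave a 1.1-fold higher number from compound 1 to compound 2 (0.04 log units; within the scatter). The core of compound 3 differs from the core of compound 1, but that difference is not broken down here.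

Compound 4, `COc1ccc(OC)c(/C=C/C(=O)C(=Cc2ccc(O)c(F)c2)C(=O)/C=C/c2cc(OC)ccc2OC)c1`, has not yet been measured in this assay. It stands to compound 3 as compound 2 stands to compound 1: the change is 3-fluoro-4-hydroxyphenyl in place of 3,4-dimethoxyphenyl on a double-bonded chain carbon bound to a double-bonded chain carbon, the same change at the same place. Because the earlier instance gave a 1.1-fold higher number from compound 1 to compound 2 (0.04 log units; within the scatter), the step from compound 3 to compound 4 is expected to be similarly small, about a 1.1-fold higher number from compound 3 to compound 4 (0.05 log units; within the scatter). Compound 4 is therefore estimated to give 290 nM in this assay, with a likely range from 150 nM to 560 nM.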

Compound 4, half-maximal inhibitory concentration: 220 nM
The estimate for compound 4 lay 1.3-fold (0.12 log units) above the measured number; the range from low to high includes it.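

In this assay, the same replacement on the core of compound 3, 3-fluoro-4-hydroxyphenyl in place of 3,4-dimethoxyphenyl, gave a 1.2-fold lower number from compound 3 to compound 4 (0.07 log units; within the scatter). Set beside the earlier instance, the two steps do not differ: the same change on two cores in this assay, a 1.1-fold higher number (0.04 log units; within the scatter) from compound 1 to compound 2 and a 1.2-fold lower number (0.07 log units; within the scatter) from compound 3 to compound 4, 1.3-fold (0.11 log units) apart, within the scatter of two such steps. This shows that on these two cores the change left the number within the scatter both times, so the small size of the step carried from one core to the other, but it gives the step no reliable direction and does not show that the same would hold on any further core of the series.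

The compounds shown leave open whether a group of another kind at this place, such as an aryl ring bearing an amine or a carboxylic acid, would move the number beyond the scatter. They also leave open what the fluorine and the hydroxyl of 3-fluoro-4-hydroxyphenyl each contribute alone.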